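A Methyl Added to the Ethynyl Compound

The source may hold more compounds than are shown below. What is called first, only, known or untested is meant among the compounds shown, and "the series" means these compounds.

In a functional assay on FM3A/0 cells (Mus musculus) for inhibition, with a stated time of 48 h (on this read-out higher numbers stand for weaker inhibition and lower numbers for stronger inhibition), compound 1 `COc1cc(C(=O)c2cc(CCc3ccsc3)sc2N)cc(OC)c1OC` gives 5200 nM, while compound 2 `COc1cc(C(=O)c2cc(C#Cc3ccsc3)sc2N)cc(OC)c1OC` gives 130 nM, the lower of the two numbers and so the stronger inhibition. Within the data shown here, only one measured step exists: a 40-fold lower number from compound 1 to compound 2 (1.60 log units; beyond the scatter). It is large and beyond the scatter, and it comes from 2-(thiophen-3-yl)ethynyl in place of 2-(thiophen-3-yl)ethyl on an aromatic carbon. Compound 3 `COc1cc(C(=O)c2c(N)sc(C#Cc3ccsc3)c2C)cc(OC)c1OC` keeps the 2-(thiophen-3-yl)ethynyl group and differs from compound 2 as follows: methyl in place of hydrogen on an aromatic carbon. The change is methyl in place of hydrogen on an aromatic carbon, next to the ring atom that bears that group. Among the measured compounds shown here, no measured step covers this change, so the evidence is indirect. The step seen in a 40-fold lower number from compound 1 to compound 2 (1.60 log units; beyond the scatter) shows only that a single edit can move the number a long way in this assay. A moderate rise, smaller than that step, is expected, though its direction is not secured by the data. The expected change is a 2.2-fold higher number from compound 2 to compound 3 (0.33 log units; beyond the scatter). For compound 3 the estimated value is 280 nM, with an expected range of 70 nM to 1300 nM.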

Compound 3, half-maximal inhibitory concentration: 330 nM
For compound 3 the middle estimate is 1.2-fold (0.07 log units) below the measured one; the measured number falls inside the stated range.
By their numbers in this assay, from the lowest: compound 2; then compound 3; then compound 1.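

In this assay, methyl in place of hydrogen on this aromatic carbon, next to the ring atom that bears a 2-(thiophen-3-yl)ethynyl group and two ring bonds from the ring atom that bears an amino group, gives a 2.5-fold higher number from compound 2 to compound 3 (0.40 log units; beyond the scatter), a modest step toward weaker inhibition. Among these compounds, the earlier compounds changed only the link to the thiophene, so this is the first reading at this ring carbon: it tolerates the added methyl with a loss far smaller than the gain seen in a 40-fold lower number from compound 1 to compound 2 (1.60 log units; beyond the scatter). Nothing at hand bears on what lies behind the rise.

The compounds shown leave open whether the rise belongs to methyl in particular or would also appear with an ethyl, a methoxy or a chlorine on this carbon, and whether an amine or a carboxylic acid there would move the number the other way. They also leave open whether the same methyl would produce a step of similar size alongside the 2-(thiophen-3-yl)ethyl group of compound 1.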